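The compounds below may be only part of what the source reports. "The series", "measured", "known", "first", "only" and "open" are said of these compounds alone.

Measured compounds in the series:

compound 1 `O=C(/C=C/c1ccc2c(c1)B(O)OC2)c1ccc(Br)cc1` — > 10 ug/mL
compound 2 `COc1cccc(C(=O)/C=C/c2ccccc2)c1` — 5.7 ug/mL
compound 3 `COc1cccc(C(=O)CCc2ccc3c(c2)B(O)OC3)c1` — > 10 ug/mL

Three compounds have been run in an ADME assay on L929 cells (Mus musculus) for cytotoxicity, read by resazurin assay, with a stated time of 72 h; on this read-out higher numbers stand for weaker inhibition and lower numbers for stronger inhibition. Compound 1 returns only a limit in this assay, > 10 ug/mL, not a number. Compound 3 likewise returns only a limit in this assay, > 10 ug/mL. Going by the values given here, compound 2 is the single compound with a numeric read-out in this assay, 5.7 ug/mL. Compound 1 therefore stands at the edge of what this assay reports, together with compound 3, as shown by the limit of > 10 ug/mL in this assay, at which 2 of the 3 values shown sit, while compound 2 sits lower.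

The next compound is compound 4 `O=C(/C=C/c1ccc2c(c1)B(O)OC2)c1ccc(F)cc1`. Relative to compound 1 the change is fluoro in place of bromo on an aromatic carbon. Among the compounds with values here, no pair of measured compounds differing in a single place is available, so no measured step can be pointed to for this change. Given that compound 1 itself is at the limit > 10 ug/mL, compound 4 is expected to come out near the same limit, with a step from compound 1 of a step that the limit leaves unreadable from compound 1 to compound 4, within the usual scatter or none beyond it. The estimate for compound 4 in this assay is 12 ug/mL, in the range 5 ug/mL to 30 ug/mL.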

Compound 4, half-maximal inhibitory concentration: > 10 ug/mL
Compound 4 ended at the assay's limit; the forecaster's own chance of this, stated with the estimate: 65%; the middle value does not contradict the limit.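

Compound 1 and compound 4 each return only a limit, so no step can be read for fluoro in place of bromo on an aromatic carbon: the limit of > 10 ug/mL in this assay, at which 3 of the 4 values shown sit.

The compounds shown leave open whether 4-bromophenyl and 4-fluorophenyl differ at all in this read-out, since neither compound has a numeric value.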